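The source may hold more compounds than are shown below. What is called first, only, known or untested is meant among the compounds shown, and "the series" means these compounds.

The three measured compounds share one core. Compound 1 has the structure `CC1CCN(C(=S)SCc2ccc(C(=O)Nc3ccccc3N)cc2)CC1`, compound 2 the structure `Cc1ccc(N2CCN(C(=S)SCc3ccc(C(=O)Nc4ccccc4N)cc3)CC2)cc1` and compound 3 the structure `CN(Cc1cccnc1)C(=S)SCc1ccc(C(=O)Nc2ccccc2N)cc1`. In a functional assay on HeLa cells (Homo sapiens) for antiproliferative activity, read by CCK-8 assay, with a stated time of 72 h, tested at 2 uM (a higher number here means a stronger effect of the compound at the concentration tested, a lower number a weaker effect), compound 1 gives 46.8%, compound 2 gives 25.3% and compound 3 gives 16.4%. Compound 2 thus stands second highest of the three: its gap to compound 3 lies within the scatter, while compound 1 stands beyond the scatter above it. Within the data shown here, the only step between measured compounds that differ in one place is a number 30.4 percentage points lower from compound 1 to compound 3 (beyond the scatter), and it concerns the group on the thiocarbonyl carbon.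

Compound 4, with the structure `Nc1ccccc1NC(=O)c1ccc(CSC(=S)N2CCN(c3cnccn3)CC2)cc1`, differs from compound 2 in another place: pyrazin-2-yl in place of 4-methylphenyl on an amine nitrogen in a ring. Among the measured compounds shown here, no measured step changes the group on the amine nitrogen in the ring, so the single known step offers no direct guide to this change, and the data give no reason to expect a large move in either direction. The step of a number 2.7 percentage points higher from compound 2 to compound 4 (within the scatter) that the estimate means is therefore expected to stay within the scatter. For compound 4 the estimate in this assay is 28%, with a range from 12% to 45%.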

Compound 4, a percentage reported as inhibition, at one concentration (the size of the read-out at that concentration, not a potency): 70.4%
Beside the measured number, compound 4's estimate is 42.4 percentage points below it, outside the stated range (above it).
By their numbers in this assay, from the lowest: compounds 3 and 2 (each within the scatter of the next); then compound 1; then compound 4.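

In this assay, among these compounds, the group on the amine nitrogen in the ring turns out to have a strong influence on the read-out: the step is a number 45.1 percentage points higher from compound 2 to compound 4 (beyond the scatter), which is large and is the only measured change at this position. Pyrazin-2-yl, with 2 nitrogen atoms and 2 hydrogen-bond acceptors, replaces 4-methylphenyl, which has 7 carbon atoms and no hydrogen-bond acceptors, so the earlier step on the thiocarbonyl carbon is no longer the only large step and this second place in the molecule also moves the number widely. Nothing measured here accounts for the size of this step.

This single pair cannot separate the entry of the ring nitrogen atoms from the loss of the methyl group, and the compounds shown leave open how a plain phenyl, a pyridin-2-yl or a pyrimidin-2-yl group would stand on the same nitrogen. They also leave open whether the step would hold at other concentrations, since the read-out gives the size of the effect at one concentration and not a potency.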